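The source may hold more compounds than are shown below. What is called first, only, known or untested is meant among the compounds shown, and "the series" means these compounds.

Three compounds built on a shared core have numbers in a functional assay on GBM1 cells (Homo sapiens) for antiproliferative activity, read by WST assay, with a stated time of 72 h; a higher number here means a weaker inhibitor, a lower number a stronger inhibitor. Compound 1 `O=C(Nc1cc2ncncc2cc1OCc1ccc(Cl)cc1)Nc1cccc2ccccc12` gives 7900 nM, compound 2 `O=C(Nc1ccccc1F)Nc1cc2ncncc2cc1OCc1ccccc1` gives 6100 nM, and compound 3 `O=C(Nc1cccc(F)c1)Nc1cc2ncncc2cc1OCc1ccccc1Cl` gives 4000 nM. Compound 3 stands within the usual scatter of both of the others, so these numbers do not separate the three.

Compound 4 `O=C(Nc1cccc(F)c1)Nc1cc2ncncc2cc1OCc1cccc(Cl)c1` has not yet been measured in this assay. It has the same atoms as compound 3, joined differently: 3-chlorophenyl in place of 2-chlorophenyl on a saturated chain carbon bound to an oxygen on an aromatic ring. In words, 3-chlorophenyl takes the place of 2-chlorophenyl on a saturated chain carbon bound to an oxygen on an aromatic ring.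

For the measured compounds named here, no measured pair in this set differs in one place only, so there is no direct precedent for this change. Going by the values given here, the only guide is the spread of the measured compounds. Compound 1 at 7900 nM and compound 3 at 4000 nM differ in more than one place and still remain within the scatter of each other. On that basis, no step beyond the scatter is expected here, and no direction is strongly favoured. The estimated change is a 1.1-fold higher number from compound 3 to compound 4 (0.05 log units; within the scatter). For compound 4 the expected value is 4500 nM, with an estimated range of 2000 nM to 9000 nM.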

Compound 4, half-maximal inhibitory concentration: 3700 nM
Compound 4: the middle estimate sits 1.2-fold (0.09 log units) above what was measured, and the stated range covers the measured number.
By their numbers in this assay, from the lowest: compounds 4, 3, 2 and 1 (each within the scatter of the next, the first and the last beyond it).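

For the compounds shown here, this is the first pair in the set that differs in one place only. In this assay, going by these compounds alone, 3-chlorophenyl in place of 2-chlorophenyl on a saturated chain carbon bound to an oxygen on an aromatic ring gives a 1.1-fold lower number from compound 3 to compound 4 (0.03 log units; within the scatter), so with the rest of the structure held fixed, this swap of two chlorophenyl isomers does not separate the two compounds, something the earlier compounds, which differ in more than one place, could not show. Nothing measured here offers an explanation for this result.

On these data alone, this reading rests on a single pair with one chlorine-bearing group and one 3-fluorophenyl partner on the far side of the molecule, so it remains open whether the same swap would also leave the number in place with a different partner, such as the naphthyl group of compound 1. The compounds shown also leave open what an amine or a carboxylic acid on this phenyl ring, or a longer chain in place of the saturated chain carbon, would do to the number in this assay.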